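Methyl to methoxy on the aryl ring of a shared core

A few compounds are considered here, and "the series" means these few. Any claim that something is new, unique, unknown or untested is made for them only; others in the source may bear on it.

Measured compounds:
compound 1, `COc1ccc(-c2cn(/N=C/c3cc4ccccc4nc3Cl)c(N)n2)cc1`, 31800 nM
compound 2, `Cc1ccc(-c2cn(/N=C/c3cc4cc(C)ccc4nc3Cl)c(N)n2)cc1`, 39600 nM

In a functional assay on HCT-116 cells (Homo sapiens) for cytotoxicity, read by MTT assay, with a stated time of 48 h (on this read-out lower numbers stand for stronger inhibition and higher numbers for weaker inhibition), compound 2 gives 39600 nM, the higher of the two numbers, while compound 1 gives 31800 nM, a gap that lies within the scatter. Compound 3, `COc1ccc(-c2cn(/N=C/c3cc4cc(C)ccc4nc3Cl)c(N)n2)cc1`, differs from compound 2 by methoxy in place of methyl on an aromatic carbon. Going by the values given here, no step between measured compounds isolates this change, so the expectation for compound 3 rests on the two values alone. The step from compound 2 to compound 3 is expected to be no larger than the scatter, a 1.2-fold lower number from compound 2 to compound 3 (0.08 log units; within the scatter). Compound 3 is therefore estimated at 33000 nM, within 15000 nM to 70000 nM in this assay.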

Compound 3, half-maximal inhibitory concentration: > 50000 nM
Compound 3 was reported as a limit; the forecaster's own chance of this, stated with the estimate: 10%; at least 1.5-fold (0.18 log units) between middle value and limit.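

Compound 3 is reported in this assay only as a limit, not as a number: the limit of > 50000 nM in this assay, at which 1 of the 3 values shown sits.

Going by these compounds alone, this gives the first step for 4-methylphenyl to 4-methoxyphenyl at this position, an at least 1.2-fold higher number from compound 2 to compound 3 (0.10 log units; that floor lies within the scatter), so the change has a floor but no fixed size. The step for methyl in place of hydrogen on an aromatic carbon, with methoxy in place on the aryl ring, is an at least 1.5-fold higher number from compound 1 to compound 3 (0.19 log units; that floor lies within the scatter), and neither floor separates the compounds beyond the scatter.

The compounds shown leave open how an amine or a hydroxyl group at this position would read, and how large either step truly is.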